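Growing the para substituent: from trifluoromethyl to phenyl

The compounds below may be only part of what the source reports. "The series", "measured", "known", "first", "only" and "open" are said of these compounds alone.

Compound 1, `O=C(Nc1cccc(-c2oc3cc(-c4ccc(F)cc4)ccc3c(=O)c2O)c1)c1ccc(F)cc1`, gives 6930 nM in a functional assay on A549 cells (Homo sapiens) for antiproliferative activity, read by CCK-8 assay, with a stated time of 72 h; on this read-out lower numbers stand for stronger inhibition and higher numbers for weaker inhibition.
Compound 2, `O=C(Nc1cccc(-c2oc3cc(-c4ccc(F)cc4)ccc3c(=O)c2O)c1)c1ccc(C(F)(F)F)cc1`, gives 19400 nM in this assay.
Compound 3, `CCc1ccc(C(=O)Nc2cccc(-c3oc4cc(-c5ccc(F)cc5)ccc4c(=O)c3O)c2)cc1`, gives 18500 nM in this assay.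

Compound 2 stands at the highest number of the three, though compound 3 sits right beside it: a 1.0-fold lower number from compound 2 to compound 3 (0.02 log units; within the scatter). Against compound 1 the gap is clear, as a 2.8-fold higher number from compound 1 to compound 2 (0.45 log units; beyond the scatter) shows.

Compound 4, `O=C(Nc1cccc(-c2oc3cc(-c4ccc(F)cc4)ccc3c(=O)c2O)c1)c1ccc(-c2ccccc2)cc1`, has not yet been measured. It differs from compound 2 by phenyl in place of trifluoromethyl on an aromatic carbon, so the change is phenyl in place of trifluoromethyl on an aromatic carbon, para to a large group.

Among the compounds with values here, two measured steps bear on this position. Both a 2.8-fold higher number from compound 1 to compound 2 (0.45 log units; beyond the scatter) and a 2.7-fold higher number from compound 1 to compound 3 (0.43 log units; beyond the scatter) are modest and point the same way, towards higher numbers when fluoro is replaced by a larger group, while a 1.0-fold lower number from compound 2 to compound 3 (0.02 log units; within the scatter) shows that trifluoromethyl and ethyl sit together within the scatter. Phenyl is larger again than either, and the three compounds give no example of a group of that size here. Compound 4 is therefore expected to remain near compound 2 or drift somewhat higher, with a 1.3-fold higher number from compound 2 to compound 4 (0.13 log units; within the scatter) as the estimated step. The expected value for compound 4 is 26000 nM, within a range of 9000 nM to 75000 nM.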

Compound 4, half-maximal inhibitory concentration: > 100000 nM
Compound 4: only a limit was reported; the forecaster's own chance of this, stated with the estimate: 15%; middle value at least 3.8-fold (0.58 log units) away from the limit.
By their numbers in this assay, from the lowest: compound 1; then compounds 3 and 2 (each within the scatter of the next). At a limit, above all of these: compound 4.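

In this assay, compound 4 gives only a limit of the assay, not a number: the limit of > 100000 nM in this assay, at which 1 of the 4 values shown sits. The earlier compounds had shown only modest steps at this position, with trifluoromethyl and ethyl within the scatter of each other, whereas phenyl opens a clearly wider gap from both, with an at least 5.1-fold higher number from compound 2 to compound 4 (0.71 log units; beyond the scatter) and an at least 5.4-fold higher number from compound 3 to compound 4 (0.73 log units; beyond the scatter). Set against fluoro, the change gives an at least 14-fold higher number from compound 1 to compound 4 (1.15 log units; beyond the scatter), the first large step at this position, so this aromatic carbon tolerates a phenyl ring far less well than any of the three groups seen before.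

The limit leaves the true value of compound 4 unknown, and with it the full size of these steps. As far as these compounds go, it also stays open whether a saturated ring such as cyclohexyl, a pyridine ring, or a polar group such as an amine or a carboxylic acid on this carbon would behave like phenyl or like fluoro.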